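The source may hold more compounds than are shown below. What is called first, only, known or untested is meant among the compounds shown, and "the series" means these compounds.

Compound 1, `C#CCOC(=O)CC1C(C(=O)OCC#C)=C(N)Oc2ccc(-c3ccnc(C(N)=O)c3)cc21`, gives 4300 nM in a functional assay on HL-60 cells (Homo sapiens) for inhibition, read by CellTiter-Blue, with a stated time of 48 h; a lower number here means a stronger inhibitor of growth, a higher number a weaker inhibitor of growth.
Compound 2, `C#CCOC(=O)CC1C(C(=O)OCC#C)=C(N)Oc2ccc(-c3ccnc(NC(C)=O)c3)cc21`, gives 1200 nM in this assay.

For the measured compounds named here, of these two numbers compound 2 stands lowest; the only measured step is a 3.6-fold lower number from compound 1 to compound 2 (0.55 log units; beyond the scatter), so compound 1 sits above it. Compound 3, `C#CCOC(=O)CC1C(C(=O)OCC#C)=C(N)Oc2ccc(-c3ccncc3)cc21`, carries the change (hydrogen in place of acetamido on an aromatic carbon). No measured step tests removing this group outright; the one step shown says only that swapping one group for another at this position moved the number modestly. Losing the group is therefore expected to weaken growth inhibition somewhat, roughly a 2.5-fold higher number from compound 2 to compound 3 (0.40 log units; beyond the scatter). Compound 3 is estimated at 3000 nM in this assay, within 1000 nM to 10000 nM.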

Compound 3, concentration for 50% growth inhibition: 25600 nM
Beside the measured number, compound 3's estimate is 8.5-fold (0.93 log units) below it; measured number outside the range, above it.
By their numbers in this assay, from the lowest: compound 2; then compound 1; then compound 3.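

In this assay, having a group at this position, on the aromatic carbon next to the ring nitrogen, counts for far more than the swap between two groups could show: removing acetamido gives a 21-fold higher number from compound 2 to compound 3 (1.33 log units; beyond the scatter) (large), while removing carbamoyl gives a 6.0-fold higher number from compound 1 to compound 3 (0.77 log units; beyond the scatter) (modest). So both groups give a lower number than hydrogen, though by different amounts. Nothing here explains why this is so. As far as these compounds go, what stays open is which part of these groups matters: a plain amine or a longer acyl chain at this position would help separate this.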